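The source may hold more compounds than are shown below. What is called first, only, known or untested is meant among the compounds shown, and "the series" means these compounds.

Measured compounds in a functional assay, read by spectrophotometry, with a stated time of 5 min; on this read-out higher numbers stand for weaker inhibition and lower numbers for stronger inhibition:
Compound 1, `COc1cc(/C=C/C(=O)C(=Cc2ccc(O)cc2)C(=O)/C=C/c2ccc(O)c(OC)c2)ccc1O`, gives 6320 nM.
Compound 2, `COc1cc(/C=C/C(=O)C(=Cc2ccc(O)c(O)c2)C(=O)/C=C/c2ccc(O)c(OC)c2)ccc1O`, gives 2200 nM.
Compound 3, `CCOc1cc(/C=C/C(=O)C(=Cc2ccc(O)cc2)C(=O)/C=C/c2ccc(O)c(OCC)c2)ccc1O`, gives 14800 nM.

Compound 2 differs from compound 1 by one change, (hydroxy in place of hydrogen on an aromatic carbon), and this change produced a 2.9-fold lower number from compound 1 to compound 2 (0.46 log units; beyond the scatter). Compound 3 carries a different core; how its core differs from that of compound 1 is not broken down here, and its numbers simply show that compound 3 stands highest of the three in this assay. Compound 4, `CCOc1cc(/C=C/C(=O)C(=Cc2ccc(O)c(O)c2)C(=O)/C=C/c2ccc(O)c(OCC)c2)ccc1O`, is related to compound 3 by the same change, (hydroxy in place of hydrogen on an aromatic carbon), made on the core of compound 3. The step of a 2.9-fold lower number from compound 3 to compound 4 (0.46 log units; beyond the scatter) is expected to be similar in size to the earlier one, since this rests on the measured 2.9-fold lower number from compound 1 to compound 2 (0.46 log units; beyond the scatter). Compound 4 is therefore estimated at 5100 nM, with a likely range from 2500 nM to 10500 nM in this assay.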

Compound 4, half-maximal inhibitory concentration: 3630 nM
Beside the measured number, compound 4's estimate is 1.4-fold (0.15 log units) above it, and the stated range covers the measured number.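

On the core of compound 3, the change from 4-hydroxyphenyl to 3,4-dihydroxyphenyl gave a 4.1-fold lower number from compound 3 to compound 4 (0.61 log units; beyond the scatter) in this assay, so the number fell on this core as well. Set beside the earlier step, the size of the change held across the two cores: the same change on two cores in this assay, a 2.9-fold lower number (0.46 log units; beyond the scatter) from compound 1 to compound 2 and a 4.1-fold lower number (0.61 log units; beyond the scatter) from compound 3 to compound 4, 1.4-fold (0.15 log units) apart, within the scatter of two such steps. This supports carrying the change between these two cores in this assay, but two pairs do not show that it would hold on any other core in the series.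

The compounds shown leave open whether an amine or a carboxylic acid at the same place would give a similar step. They also leave open whether the hydroxy step would persist on a core bearing propoxy groups.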